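Swapping methoxy for chloro on the aniline-type ring

The compounds below may be only part of what the source reports. "The series", "measured", "known", "first", "only" and "open" are said of these compounds alone.

Measured in a functional assay on K562 cells (Homo sapiens) for cytotoxicity, read by MTT assay, with a stated time of 72 h; on this read-out lower numbers stand for stronger inhibition and higher numbers for weaker inhibition:
Compound 1 `CC(=O)c1ccc(/N=C2\C=C(OCc3cn(S(=O)(=O)c4ccc(C)cc4)nn3)C(=O)c3ccccc32)cc1` gives 5520 nM
Compound 2 `Cc1ccc(/N=C2\C=C(OCc3cn(S(=O)(=O)c4ccc(C)cc4)nn3)C(=O)c3ccccc32)cc1` gives 6220 nM
Compound 3 `COc1ccc(/N=C2\C=C(OCc3cn(S(=O)(=O)c4ccc(C)cc4)nn3)C(=O)c3ccccc32)cc1` gives > 20000 nM

The value for compound 3 is a limit and not a number (the limit of > 20000 nM in this assay, at which 1 of the 3 values shown sits). Compound 4 `Cc1ccc(S(=O)(=O)n2cc(COC3=C/C(=N\c4ccc(Cl)cc4)c4ccccc4C3=O)nn2)cc1` has not yet been measured. It differs from compound 3 by one change, 4-methoxyphenyl to 4-chlorophenyl, with chloro in place of methoxy on an aromatic carbon.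

Among the compounds with values here, no chloro compound has a measured value, so the closest guide comes from the two steps that end at methoxy, read in reverse. These are an at least 3.6-fold higher number from compound 1 to compound 3 (0.55 log units; beyond the scatter) and an at least 3.2-fold higher number from compound 2 to compound 3 (0.50 log units; beyond the scatter). The step between the other two groups is small, a 1.1-fold higher number from compound 1 to compound 2 (0.05 log units; within the scatter).

Both other groups thus give lower numbers than methoxy, and chloro is expected to do the same, by a similar size of step. The expected change is an at least 3.0-fold lower number from compound 3 to compound 4 (0.48 log units; beyond the scatter). For compound 4 the estimated value is 6500 nM, with an expected range of 2500 nM to 18000 nM.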

Compound 4, half-maximal inhibitory concentration: 9800 nM
Compound 4: the middle estimate sits 1.5-fold (0.18 log units) below what was measured; low and high end bracket the measured number.
By their numbers in this assay, from the lowest: compounds 1, 2 and 4 (each within the scatter of the next). At a limit, above all of these: compound 3.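

Chloro on this ring in this assay gives a number that cannot be told apart from those of the methyl compound (a 1.6-fold higher number from compound 2 to compound 4 (0.20 log units; within the scatter)) and the acetyl compound (a 1.8-fold higher number from compound 1 to compound 4 (0.25 log units; within the scatter)), so three different groups at this place now read alike. Against the methoxy compound the step is only a floor (an at least 2.0-fold lower number from compound 3 to compound 4 (0.30 log units; that floor lies within the scatter)), and that floor does not clear the usual scatter, so chloro cannot yet be firmly separated from methoxy. The value of compound 3 is a limit and not a number: the limit of > 20000 nM in this assay, at which 1 of the 4 values shown sits.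

The compounds shown leave open how far compound 3 truly sits from the other three. They also leave open whether an amine, a carboxylic acid or plain hydrogen at this place would read like chloro, methyl and acetyl.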